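Adding a methoxy group to compound 2

The compounds below may be only part of what the source reports. "The series", "measured", "known", "first", "only" and "open" are said of these compounds alone.

The compounds measured so far in a functional assay on M14 cells (Homo sapiens) for inhibition, read by sulforhodamine B assay, with a stated time of 48 h (a lower number here means a stronger inhibitor of growth, a higher number a weaker inhibitor of growth), are these
Compound 1 `COc1cc(C(=O)NNC(=O)c2ccc3[nH]c(-c4ccc([N+](=O)[O-])s4)nc3c2)cc(OC)c1OC` gives 62.5 ug/mL
Compound 2 `COc1ccc(C(=O)NNC(=O)c2ccc3[nH]c(-c4ccc([N+](=O)[O-])o4)nc3c2)cc1OC` gives 15.6 ug/mL

Compound 2 at 15.6 ug/mL holds the lower of the two numbers, and its gap to compound 1 lies beyond the scatter. Compound 3 `COc1cc(C(=O)NNC(=O)c2ccc3[nH]c(-c4ccc([N+](=O)[O-])o4)nc3c2)cc(OC)c1OC` starts from compound 2 and makes a single change (methoxy in place of hydrogen on an aromatic carbon), methoxy in place of hydrogen on an aromatic carbon. Compound 1 shares this added methoxy with compound 3 but differs from it elsewhere, so compound 1 at 62.5 ug/mL offers only a loose guide. A modest weakening is expected in this assay (a 1.6-fold higher number from compound 2 to compound 3 (0.20 log units; within the scatter)), a step toward a higher number that would stay within the scatter. Compound 3 is estimated at 25 ug/mL with 10 ug/mL to 62.5 ug/mL as the expected range.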

Compound 3, concentration for 50% growth inhibition: 15.6 ug/mL
The estimate for compound 3 lay 1.6-fold (0.20 log units) above the measured number; low and high end bracket the measured number.
By their numbers in this assay, from the lowest: compounds 2 and 3 (each within the scatter of the next); then compound 1.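

In this assay, a further methoxy on the aromatic ring, ortho to a methoxy group and meta to a large group, gives no change at the digits printed from compound 2 to compound 3 (within the scatter) and so shows that this position accepts the added group in this assay without a change beyond the scatter. With that methoxy now common to both compounds, 5-nitrofuran-2-yl in place of 5-nitrothiophen-2-yl can be read as a single change, and it gives a 4.0-fold lower number from compound 1 to compound 3 (0.60 log units; beyond the scatter) as the step between them. Nothing given here accounts for either result.

On these data alone, it remains open whether this position would accept an amine, a carboxylic acid or a longer alkoxy chain as it accepts methoxy. As far as these compounds go, it also remains open whether the step from 5-nitrothiophen-2-yl to 5-nitrofuran-2-yl would be of similar size without the added methoxy.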